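Amide substituent changes across a shared core

This account rests on a few compounds, and the source may have more. Where it says the series, first, only, none or still open, it means among the compounds named here.

Of the compounds shown here, three have been measured in a functional assay on MCF7 cells (Homo sapiens) for inhibition, read by MTT assay, with a stated time of 48 h; on this read-out higher numbers stand for weaker inhibition and lower numbers for stronger inhibition. Compound 1 `COc1cc2cc(C(=O)NCCCc3ccccc3)c(=O)oc2cc1OCCCOc1no[n+]([O-])c1S(=O)(=O)c1ccccc1` gives 870 nM in this assay and stands second highest of the three numbers. Its nearest neighbour, compound 3 `COc1cc2cc(C(=O)NCc3ccccc3)c(=O)oc2cc1OCCCOc1no[n+]([O-])c1S(=O)(=O)c1ccccc1`, gives 740 nM, and the furthest, compound 2 `COc1cc2cc(N)c(=O)oc2cc1OCCCOc1no[n+]([O-])c1S(=O)(=O)c1ccccc1`, gives 2020 nM. The step of a 1.2-fold lower number from compound 1 to compound 3 (0.07 log units; within the scatter) shows that shortening the chain between the amide nitrogen and the phenyl ring leaves the number where it is, while the step of a 2.3-fold higher number from compound 1 to compound 2 (0.37 log units; beyond the scatter) shows that removing the carbamoyl group altogether gives a modestly higher number.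

Compound 4 `COc1cc2cc(C(=O)Nc3ccc(F)cc3)c(=O)oc2cc1OCCCOc1no[n+]([O-])c1S(=O)(=O)c1ccccc1` differs from compound 1 in one place: 4-fluorophenyl in place of 3-phenylpropyl on an amide-type nitrogen. An aromatic ring is kept, but as a 4-fluorophenyl group placed on the amide nitrogen itself. The step of a 1.2-fold lower number from compound 1 to compound 3 (0.07 log units; within the scatter) is the only measured one that bears on this change, and it was within the scatter. For the measured compounds named here, no measured compound carries an aryl group on the amide nitrogen, so that arrangement is not covered by any measured step. The step of a 2.3-fold higher number from compound 1 to compound 2 (0.37 log units; beyond the scatter) marks the size reached when the whole amide substituent is lost, and keeping an aromatic ring should fall well short of that. Compound 4 is therefore expected to give about 800 nM in this assay, with a range from 350 nM to 1800 nM. The step of a 1.1-fold lower number from compound 1 to compound 4 (0.04 log units; within the scatter) is expected to lie within the scatter.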

Compound 4, half-maximal inhibitory concentration: 860 nM
Compound 4: the middle estimate sits 1.1-fold (0.03 log units) below what was measured, and the stated range covers the measured number.
By their numbers in this assay, from the lowest: compounds 3, 4 and 1 (each within the scatter of the next); then compound 2.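

With an aryl group set directly on the amide nitrogen, this assay still gives no separation: a 1.0-fold lower number from compound 1 to compound 4 (0.01 log units; within the scatter) and a 1.2-fold higher number from compound 3 to compound 4 (0.07 log units; within the scatter) are the two steps, and so 4-fluorophenyl, benzyl and 3-phenylpropyl on this amide-type nitrogen cannot be told apart, with or without a saturated chain to the aromatic ring. The separation from the amino compound persists with this new substituent, as a 2.3-fold lower number from compound 2 to compound 4 (0.37 log units; beyond the scatter) shows, and all three carbamoyl compounds now stand apart from compound 2 with no exception among the compounds shown. No supporting data are available to explain why these three substituents read alike.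

The compounds shown leave open whether the aromatic ring on the amide nitrogen is needed at all, since a small alkyl group such as methyl, a chain ending in an amine or a carboxylic acid, or the unsubstituted amide could read differently. They also leave open what the fluorine contributes, which a plain phenyl group or a 4-chlorophenyl group on the same nitrogen would help to settle.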